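A few compounds are considered here, and "the series" means these few. Any claim that something is new, unique, unknown or untested is made for them only; others in the source may bear on it.

Of the compounds shown here, three built on one shared core have been measured so far. Compound 1 `c1ccc(-c2cn3ccnc3c(-c3ccc4ncn(C5CCCCC5)c4c3)n2)cc1` gives 9.15% in a functional assay on SW-620 cells (Homo sapiens) for inhibition, read by sulforhodamine B assay, with a stated time of 48 h, tested at 10 uM; on this read-out higher numbers stand for more inhibition at the one concentration tested (going by the name of the read-out) and lower numbers for less inhibition. Compound 2 `Fc1ccc(-c2cn3ccnc3c(-c3ccc4ncn(C5CCCCC5)c4c3)n2)cc1` gives 8.38% in this assay, and compound 3 `Brc1ccc(-c2cn3ccnc3c(-c3ccc4ncn(C5CCCCC5)c4c3)n2)cc1` gives 21.9%. Compound 3 stands highest of the three, and both gaps lie beyond the scatter: a number 12.8 percentage points higher from compound 1 to compound 3 (beyond the scatter) and a number 13.5 percentage points higher from compound 2 to compound 3 (beyond the scatter), whereas a number 0.8 percentage points lower from compound 1 to compound 2 (within the scatter).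

Compound 4 `COc1ccccc1-c1cn2ccnc2c(-c2ccc3ncn(C4CCCCC4)c3c2)n1` has not yet been measured in this assay. 2-methoxyphenyl in place of 4-bromophenyl on an aromatic carbon The measured steps bear only on the bromine that leaves: bromo in place of hydrogen and bromo in place of fluoro each raised the read-out by a modest amount, so taking the bromo away is expected to undo a modest gain and bring the number back toward where compound 1 and compound 2 stand. Nothing measured speaks to 2-methoxyphenyl itself, so the direction of that part of the change is open. The expected step is a number 10.9 percentage points lower from compound 3 to compound 4 (beyond the scatter). Compound 4 is therefore estimated at 11%, with a range from 0% to 25%.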

Compound 4, a percentage reported as inhibition, at one concentration (the size of the read-out at that concentration, not a potency): 3.4%
Estimate against measurement, compound 4: 7.6 percentage points above, within the range that was stated.
By their numbers in this assay, from the lowest: compounds 4, 2 and 1 (each within the scatter of the next); then compound 3.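

Among the compounds shown here, with a number 18.5 percentage points lower from compound 3 to compound 4 (beyond the scatter) for 2-methoxyphenyl in place of 4-bromophenyl in this assay, this position now shows a step down beyond the scatter, and compound 3 remains the only compound set apart. The other two steps, a number 5 percentage points lower from compound 2 to compound 4 (within the scatter) and a number 5.8 percentage points lower from compound 1 to compound 4 (within the scatter), show that 2-methoxyphenyl is not separated from 4-fluorophenyl or the unsubstituted phenyl, so among the four compounds only the 4-bromophenyl group changes the read-out beyond the scatter. Nothing available here accounts for this result.

The compounds leave open whether the gain belongs to bromine or to the place it occupies, since 2-bromophenyl and 4-methoxyphenyl do not appear among them. They also leave open how 4-chlorophenyl, 4-aminophenyl or a 4-carboxyphenyl group would read at this position.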